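Swapping the Substituent on a Piperidine Urea

The source may report more compounds than this note shows. Statements on the series, on what has been measured and on what is new or still open speak of the compounds shown alone.

Compound 1, `O=C(C1CCCO1)N1CC(c2nc(-c3cccc(Cl)c3)no2)C1`, gives > 10000 nM in an assay on HEK293 cells for positive allosteric modulation of metabotropic glutamate receptor 5 (Homo sapiens), read by FLIPR; a lower number here means that less compound is needed, a higher number that more compound is needed for the effect; this is a limit of the assay, not a number.
Compound 2, `O=C(c1cccc(F)c1)N1CC(c2nc(-c3cccc(Cl)c3)no2)C1`, gives > 10000 nM in this assay; this too is a limit.
Compound 3, `CC1CCN(C(=O)N2CC(c3nc(-c4cccc(Cl)c4)no3)C2)CC1`, gives 865 nM in this assay.

Among the compounds with values here, compound 3 thus holds the only real number among the three; the other two sit at the limit of > 10000 nM in this assay, at which 2 of the 3 values shown sit. Both measured steps lead to it: an at least 11-fold lower number from compound 1 to compound 3 (1.06 log units; beyond the scatter) and an at least 11-fold lower number from compound 2 to compound 3 (1.06 log units; beyond the scatter), each at least large, so the piperidine urea is what brought the value into readable range.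

Compound 4, `COC1CCCN(C(=O)N2CC(c3nc(-c4cccc(Cl)c4)no3)C2)C1`, keeps that piperidine urea and changes only the substituent on the ring: 3-methoxypiperidin-1-yl in place of 4-methylpiperidin-1-yl on a carbonyl carbon. No measured step touches this kind of change; the two steps shown replace a whole group at the carbonyl carbon, whereas here the ring stays and only its substituent differs. Within a single ring type the expectation is a small step in this assay, if any beyond the scatter, with a modest loss slightly more likely than a gain. The estimate for compound 4 is therefore 1300 nM, between 400 nM and 4500 nM, meaning an expected step of a 1.5-fold higher number from compound 3 to compound 4 (0.18 log units; within the scatter).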

Compound 4, half-maximal effective concentration: > 10000 nM
Compound 4: only a limit was reported; the forecaster's own chance of this, stated with the estimate: 25%; middle value at least 7.6-fold (0.88 log units) from the limit.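

The piperidine urea alone does not secure a readable value in this assay, as the substituent on the ring also counts: 3-methoxypiperidin-1-yl in place of 4-methylpiperidin-1-yl on the carbonyl carbon gives an at least 11-fold higher number from compound 3 to compound 4 (1.06 log units; beyond the scatter). Compound 4 gives > 10000 nM, which is a limit of the assay and not a number, and it joins the other compounds at that ceiling: the limit of > 10000 nM in this assay, at which 3 of the 4 values shown sit. Compound 3 therefore remains the only one of the four with a real number, and the steps from compound 1 and compound 2 to compound 4 cannot be read, as both ends of each are limits.

This single swap changes both the group on the ring and where it sits, so the compounds shown cannot tell which of the two matters, or how far above the limit compound 4 really lies. Also open, as far as these compounds go, is how the bare piperidin-1-yl ring would behave, and whether an ethyl or a hydroxyl group on the ring would keep a readable value or lose it as well.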